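Taking the hydroxy off compound 2

The compounds below may be only part of what the source reports. "The series", "measured", "known", "first", "only" and "open" are said of these compounds alone.

In a functional assay on HUVEC cells (Homo sapiens) for inhibition, read by ELISA and BrdU incorporation (on this read-out lower numbers stand for stronger inhibition and higher numbers for weaker inhibition), compound 1 (`Cc1cc(Cl)cc(C(=O)Nc2cnc3ccccc3c2)c1`) gives 76.3 nM as its half-maximal inhibitory concentration. Compound 2 (`Cc1cc(Br)cc(C(=O)Nc2cnc3ccccc3c2)c1O`) gives 18.9 nM in the same test. Compound 2 therefore holds the lower of the two numbers, and the gap between them lies beyond the usual scatter of repeated measurements.

The next step leads to compound 3 (`Cc1cc(Br)cc(C(=O)Nc2cnc3ccccc3c2)c1`), which has hydrogen in place of hydroxy on an aromatic carbon. That carbon is ortho to a large group, ortho to a methyl group and para to a bromo group.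

No two measured compounds differ by this change alone, so its size has not been shown directly. Among the compounds with values here, the only hint is compound 1, which also lacks the hydroxy and sits at the higher number (76.3 nM). A move toward weaker inhibition, beyond the scatter, is therefore expected in this assay for this step, though one comparison is thin support. The expected change is a 3.2-fold higher number from compound 2 to compound 3 (0.50 log units; beyond the scatter) on this read-out. For compound 3 the estimated value is 60 nM (expected range 25 nM to 140 nM).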

Compound 3, half-maximal inhibitory concentration: 89.6 nM
The estimate for compound 3 lay 1.5-fold (0.17 log units) below the measured number; the measured number falls inside the stated range.
By their numbers in this assay, from the lowest: compound 2; then compounds 1 and 3 (each within the scatter of the next).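

In this assay the effect of the hydroxy at this aromatic carbon, which sits ortho to a large group, ortho to a methyl group and para to a bromo group, can now be read directly, as two compounds differ by this change alone (the step is a 4.7-fold higher number from compound 2 to compound 3 (0.68 log units; beyond the scatter)). With everything else held the same, replacing the hydroxy with hydrogen weakens inhibition by more than repeat measurements would normally vary, so this position is sensitive to what it carries, at least in this pair. The halogen change behaves differently, since swapping chloro for bromo gives a difference that cannot be told apart from noise (the step is a 1.2-fold higher number from compound 1 to compound 3 (0.07 log units; within the scatter)), and nothing available here explains either result.

As far as these compounds go, it remains open whether a methoxy group, an amine or a fluorine at the same carbon would keep the lower number seen with hydroxy or would behave like hydrogen. Also open, from the compounds shown here alone, is whether adding the hydroxy would bring the same gain when chloro replaces bromo on the ring, or when the methyl group is changed to a longer chain.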